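Aryl swap on the triazole arm of the spiro series

A few compounds are considered here, and "the series" means these few. Any claim that something is new, unique, unknown or untested is made for them only; others in the source may bear on it.

Among the compounds with values here, compound 2 `N#CC1=C(N)Oc2c(N)cc3nc4ccccc4nc3c2C12C(=O)N(Cc1cnnn1-c1cccc(C(F)(F)F)c1)c1ccccc12` is the only member of the set with a numerical result: in a functional assay on MCF7 cells (Homo sapiens) for antiproliferative activity, read by MTT assay, with a stated time of 48 h (a higher number here means a weaker inhibitor, a lower number a stronger inhibitor), compound 2 gives 31600 nM. Compound 1 `N#CC1=C(N)Oc2c(c3nc4ccccc4nc3c3ccccc23)C12C(=O)N(Cc1cnnn1-c1ccccc1Cl)c1ccccc12` reaches only a limit of this assay, > 50000 nM, a point recorded as the limit of > 50000 nM in this assay, at which 1 of the 2 values shown sits. Compound 3 `N#CC1=C(N)Oc2c(N)cc3nc4ccccc4nc3c2C12C(=O)N(Cc1cnnn1-c1ccc(Cl)cc1[N+](=O)[O-])c1ccccc12` is not yet measured; it differs from compound 2 by 4-chloro-2-nitrophenyl in place of 3-(trifluoromethyl)phenyl on an aromatic nitrogen. Within the data shown here, no measured pair isolates this kind of change, so the step from compound 2 to compound 3 is expected to stay within the scatter, a 1.1-fold lower number from compound 2 to compound 3 (0.02 log units; within the scatter). Compound 3 is therefore estimated at 30000 nM, within 10000 nM to 90000 nM.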

Compound 3, half-maximal inhibitory concentration: > 50000 nM
Compound 3 ended at the assay's limit; the forecaster's own chance of this, stated with the estimate: 35%; middle value at least 1.6-fold (0.22 log units) from the limit.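

At this position, on an aromatic nitrogen of the five-membered ring, the swap to 4-chloro-2-nitrophenyl gives the first readable step: an at least 1.5-fold higher number from compound 2 to compound 3 (0.19 log units; that floor lies within the scatter). That step is only a floor, because compound 3 rests at a limit of the assay: the limit of > 50000 nM in this assay, at which 2 of the 3 values shown sit.

The pair shows no stronger inhibition with 4-chloro-2-nitrophenyl, but it fixes no true size for the change. Still open, on these data alone, is whether chlorine or nitro alone, an unsubstituted phenyl, or an amine or carboxylic acid on this aryl ring would move the number clearly away from that limit.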